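This account rests on a few compounds, and the source may have more. Where it says the series, first, only, none or still open, it means among the compounds named here.

Compound 1 `Cc1cccc(Cn2c(CN3CCN(C(=O)c4ccc([N+](=O)[O-])cc4)CC3)nc3ccccc32)c1`: 24.3%
Compound 2 `Cc1cccc(Cn2c(CN3CCN(C(=O)c4ccc(C(C)C)cc4)CC3)nc3ccccc32)c1`: 67.6%

Going by the values given here, in an assay on isolated protein for inhibition of aldehyde dehydrogenase 1A1 (Homo sapiens), read by spectrophotometry, tested at 10 uM (on this read-out higher numbers stand for more inhibition at the one concentration tested (going by the name of the read-out) and lower numbers for less inhibition), compound 2 stands highest of the two numbers, and the only measured step, a number 43.3 percentage points higher from compound 1 to compound 2 (beyond the scatter), was large. Compound 3 `Cc1cccc(Cn2c(CN3CCN(C(=O)c4ccc(Cl)cc4)CC3)nc3ccccc32)c1` differs from compound 2 by chloro in place of isopropyl on an aromatic carbon. Among the compounds with values here, no measured step exchanges isopropyl for chloro, so the earlier step bears on it only by showing that the group on this ring carbon moves the read-out strongly. A downward step of moderate size is therefore expected, a number 22.6 percentage points lower from compound 2 to compound 3 (beyond the scatter), since chloro is a smaller group than isopropyl yet unlike nitro. Compound 3 is estimated at 45%, within 20% to 70%.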

Compound 3, a percentage reported as inhibition, at one concentration (the size of the read-out at that concentration, not a potency): 23.2%
Compound 3: middle estimate off by 21.8 percentage points, on the high side; the range from low to high includes it.
By their numbers in this assay, from the lowest: compounds 3 and 1 (each within the scatter of the next); then compound 2.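

In this assay, chloro in place of isopropyl gives a number 44.4 percentage points lower from compound 2 to compound 3 (beyond the scatter), so the higher number of compound 2 is tied to isopropyl and not merely to the absence of nitro. Chloro in place of nitro gives a number 1.1 percentage points lower from compound 1 to compound 3 (within the scatter), so these two groups cannot be told apart here, and among the three groups on this ring carbon only isopropyl stands out. Nothing available explains this result. From the compounds shown here alone, whether an amine, a methoxy group or a longer carbon chain at this place would match isopropyl stays open.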